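The source may hold more compounds than are shown below. What is called first, only, known or untested is meant among the compounds shown, and "the series" means these compounds.

In a functional assay on SK-OV-3 cells (Homo sapiens) for inhibition, read by CCK-8 assay, with a stated time of 70 h (on this read-out higher numbers stand for weaker inhibition and lower numbers for stronger inhibition), compound 1 (`O=C(O)c1cccc(COc2ccc(OCCOCCNC3CCCC3)cc2)c1`) gives > 100000 nM as a limit of the assay, not a number. Compound 2 (`O=C(O)c1ccc(COc2ccc(OCCOCCNC3CCCC3)cc2)cc1`) gives > 100000 nM and stands at a limit too. The data amount to the limit of > 100000 nM in this assay, at which 2 of the 2 values shown sit, and nothing more. Within the data shown here, the only measured step is a step that the two limits leave unreadable from compound 1 to compound 2 and offers no size to carry forward. Compound 3 (`CCOc1ccc(OCCOCCNC2CCCC2)cc1`) differs from compound 2 by methyl in place of 4-carboxyphenyl on a saturated chain carbon bound to an oxygen on an aromatic ring (methyl in place of 4-carboxyphenyl). Among the measured compounds shown here, no measured step covers this change, so no firm direction can be expected in this assay and any shift is expected to be small. The expected step is an at least 1.2-fold lower number from compound 2 to compound 3 (0.09 log units; that floor lies within the scatter) and remains an estimate. For compound 3 the expected value is 80000 nM within an estimated range of 20000 nM to 150000 nM.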

Compound 3, half-maximal inhibitory concentration: 90500 nM
Compound 3: the middle estimate sits 1.1-fold (0.05 log units) below what was measured; the range from low to high includes it.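

In this assay, among these compounds, methyl on the saturated chain carbon bound to an oxygen on an aromatic ring gives the first reading that is a number and not a limit. The steps are an at least 1.1-fold lower number from compound 2 to compound 3 (0.04 log units; that floor lies within the scatter) and an at least 1.1-fold lower number from compound 1 to compound 3 (0.04 log units; that floor lies within the scatter), so removing either carboxyphenyl group shows no change beyond the scatter. The other two readings remain limits: the limit of > 100000 nM in this assay, at which 2 of the 3 values shown sit.

From the compounds shown here alone, it remains open what a plain phenyl without the carboxylic acid, or a longer chain in place of methyl, would give at this position.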